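Dropping the Methoxy Group from Compound 3

The compounds below may be only part of what the source reports. "The series", "measured", "known", "first", "only" and "open" are said of these compounds alone.

Measured compounds:
compound 1 `C/C(=N\O)c1ccc(NC(=O)Cn2nc(-c3ccc(Cl)cc3)nc2N)cc1` — 7.09%
compound 2 `c1ccc(-c2nc3sc(-c4ccccc4)cn3n2)cc1` — 11%
compound 3 `COc1ccc(-c2nc3sc(-c4ccc(Cl)cc4)cn3n2)cc1` — 82.2%

In a functional assay on NCI-H322M cells (Homo sapiens) for inhibition, read by sulforhodamine B assay, with a stated time of 48 h, tested at 10 uM (a lower number here means less inhibition of growth, a higher number more inhibition of growth at the concentration tested), compound 3 gives 82.2%, the highest of the three numbers and well beyond the scatter from both compound 2 and compound 1. Compound 4 `Clc1ccc(-c2cn3nc(-c4ccccc4)nc3s2)cc1` has not yet been measured. It differs from compound 3 by hydrogen in place of methoxy on an aromatic carbon. For the measured compounds named here, no step between measured compounds isolates this change; compound 2, which also lacks the methoxy group but carries no chlorine, gives 11%. A step downward beyond the scatter in this assay is therefore expected for compound 4. The estimated step of a number 42.2 percentage points lower from compound 3 to compound 4 (beyond the scatter) places compound 4 at an expected 40%, within a range from 8% to 80%.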

Compound 4, percent growth inhibition at one concentration: 20%
Compound 4: the middle estimate sits 20 percentage points above what was measured; measured number inside the range.
By their numbers in this assay, from the lowest: compounds 1, 2 and 4 (each within the scatter of the next, the first and the last beyond it); then compound 3.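

In this assay, for the compounds shown here, hydrogen in place of methoxy gives a number 62.2 percentage points lower from compound 3 to compound 4 (beyond the scatter), the first direct reading of this change, and it shows that the methoxy group on this aromatic carbon carries a large part of the number of compound 3. Without the methoxy group, chloro in place of hydrogen gives only a number 9 percentage points higher from compound 2 to compound 4 (within the scatter). Nothing at hand explains this dependence on the methoxy group. On these data alone, whether the chlorine matters while the methoxy group is present stays open, as does what a hydroxyl, an ethoxy or an amine would give at this place.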